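A few compounds are considered here, and "the series" means these few. Any claim that something is new, unique, unknown or untested is made for them only; others in the source may bear on it.

Working notes on the series, read in a functional assay on KYSE-410 cells (Homo sapiens) for antiproliferative activity, read by MTT assay, with a stated time of 72 h; on this read-out lower numbers stand for stronger inhibition and higher numbers for weaker inhibition. Compound 1 (`COc1ccc(NC(=O)c2cc(=O)[nH]c3cc(Br)ccc23)cc1`) gives > 20000 nM, which is a limit of the assay. Compound 2 (`O=C(Nc1ccc(F)cc1F)c1cc(=O)[nH]c2cc(Br)ccc12`) gives > 20000 nM, also a limit. For the measured compounds named here, compound 3 (`O=C(Nc1ccccn1)c1cc(=O)[nH]c2cc(Br)ccc12`) gives 9800 nM, the only actual number in the set so far, so it has no measured neighbour to be ranked against numerically.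

The next compound is compound 4 (`O=C(Nc1ccc(F)cc1)c1cc(=O)[nH]c2cc(Br)ccc12`), and the change from compound 3 is 4-fluorophenyl in place of pyridin-2-yl on an amide-type nitrogen. Going by the values given here, no measured pair isolates this change. The expectation of weaker inhibition rests on compound 1, which also has a carbon-only ring on that nitrogen and sits at the limit > 20000 nM. It rests equally on compound 2, which shares that feature and sits at the limit > 20000 nM. The expected move is a 2.0-fold higher number from compound 3 to compound 4 (0.31 log units; beyond the scatter), in the direction of weaker inhibition, and the assay may well report only a limit. For compound 4 the estimate is 20000 nM, with an expected range of 8000 nM to 45000 nM.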

Compound 4, half-maximal inhibitory concentration: > 20000 nM
Compound 4: no number, only a limit (the forecaster's own chance of this, stated with the estimate: 60%); the middle value sits exactly at the limit.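

In this assay, the replacement of pyridin-2-yl by 4-fluorophenyl on the amide-type nitrogen gives the series its first readable single-change pair, with an at least 2.0-fold higher number from compound 3 to compound 4 (0.30 log units; that floor lies within the scatter). From the compounds shown here alone, this is only a floor, so the data do not establish a separation beyond the scatter, and the true size of the step remains unknown. The steps from compound 1 and compound 2 to compound 4 cannot be read, and the three carbon-only rings on this nitrogen cannot be ranked against one another, with each of these compounds at a limit: the limit of > 20000 nM in this assay, at which 3 of the 4 values shown sit.

Going by these compounds, whether the ring nitrogen of pyridin-2-yl is what sets compound 3 apart remains open. A pyridin-3-yl or pyrimidin-2-yl group on the same amide-type nitrogen would bear directly on that question.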